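The source may hold more compounds than are shown below. What is called first, only, known or untested is meant among the compounds shown, and "the series" means these compounds.

Measured so far in an assay on membranes from brain with Neuronal acetylcholine receptor; alpha4/beta2 (Rattus norvegicus) as the target; a lower number here means a stronger inhibitor, a higher number a weaker inhibitor:

- compound 1, `Clc1ncc(OC[C@@H]2CCCN2)cc1-c1cccnc1`: 0.021 nM
- compound 2, `Clc1ncc(OC[C@@H]2CCN2)cc1/C=C/c1ccncc1`: 0.009 nM
- compound 3, `Fc1cc(/C=C/c2cc(OC[C@@H]3CCN3)cnc2Cl)ccn1`: 0.0031 nM

Compound 3 gives the lowest number of the three in this assay; compound 2 stands nearest, compound 1 furthest. Among the measured compounds shown here, the one single-point step recorded, a 2.9-fold lower number from compound 2 to compound 3 (0.46 log units; beyond the scatter), is a fluoro in place of hydrogen on an aromatic carbon of the 2-fluoropyridin-4-yl ring and lies beyond the scatter, though modest in size.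

Compound 4, `Clc1ncc(OC[C@@H]2CCN2)cc1/C=C/c1ccnc(Br)c1`, follows on from compound 3 by bromo in place of fluoro on an aromatic carbon. For the measured compounds named here, no measured pair swaps one halogen for another at this position, so the step from compound 2 to compound 3 bears on it only indirectly: it shows that a small substituent next to the ring nitrogen is tolerated and lowers the number. Whether bromo repeats that or reverses it is not shown by any measured pair. The expected step is therefore small, a 1.3-fold higher number from compound 3 to compound 4 (0.11 log units; within the scatter), likely within the scatter. Compound 4 is estimated at 0.004 nM in this assay, with a range from 0.0015 nM to 0.012 nM.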

Compound 4, inhibition constant: 0.0052 nM
Beside the measured number, compound 4's estimate is 1.3-fold (0.11 log units) below it; low and high end bracket the measured number.
By their numbers in this assay, from the lowest: compounds 3, 4 and 2 (each within the scatter of the next, the first and the last beyond it); then compound 1.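

In this assay, the change from 2-fluoropyridin-4-yl to 2-bromopyridin-4-yl on the aromatic carbon next to the ring nitrogen gives a 1.7-fold higher number from compound 3 to compound 4 (0.22 log units; within the scatter), so this position does not separate the two halogens. Bromo in place of hydrogen gives a 1.7-fold lower number from compound 2 to compound 4 (0.24 log units; within the scatter), while fluoro in place of hydrogen gives a 2.9-fold lower number from compound 2 to compound 3 (0.46 log units; beyond the scatter), so of the two halogens only fluoro stands clear of the hydrogen compound, even though compound 3 and compound 4 themselves cannot be told apart. Nothing at hand explains why the two halogen steps read as they do.

From the compounds shown here alone, whether chloro, methyl, methoxy or an amino group on the same carbon stays in this narrow range remains open. Also open, going by these compounds, is whether bromo at this position would read the same on the core of compound 1.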